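The source may report more compounds than this note shows. Statements on the series, on what has been measured and on what is new or still open speak of the compounds shown alone.

In a functional assay on MKN-45 cells (Homo sapiens) for inhibition, read by CCK-8 assay, with a stated time of 24 h (on this read-out lower numbers stand for stronger inhibition and higher numbers for weaker inhibition), compound 1 `O=C1Nc2ccccc2/C1=C/c1ccc(-c2cn(-c3ccccc3F)nn2)cc1` gives 12500 nM. Compound 2 `O=C1Nc2ccccc2/C1=C/c1ccc(-c2cn(-c3cccc(Cl)c3)nn2)cc1` gives > 20000 nM, which is a limit of the assay and not a number. Its standing rests only on (the limit of > 20000 nM in this assay, at which 1 of the 2 values shown sits). Going by the values given here, the one measured step, an at least 1.6-fold higher number from compound 1 to compound 2 (0.20 log units; that floor lies within the scatter), changes the group on the same aromatic nitrogen, and its floor lies within the scatter, so its true size remains open.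

The next change leads to compound 3 `O=C1Nc2ccccc2/C1=C/c1ccc(-c2cn(-c3ccc(Cl)cc3)nn2)cc1`: 4-chlorophenyl in place of 3-chlorophenyl on an aromatic nitrogen. This places 4-chlorophenyl in place of 3-chlorophenyl on an aromatic nitrogen. Among the compounds with values here, no measured pair covers this exact change, and compound 2 offers only a limit as a starting point. No shift beyond the scatter is therefore expected in this assay, and neither direction is favoured. The estimated step is a number no higher from compound 2 to compound 3 (the limit leaves the size open). Compound 3 is expected at 20000 nM, with an estimated range of 8000 nM to 45000 nM.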

Compound 3, half-maximal inhibitory concentration: 16200 nM
For compound 3 the middle estimate is 1.2-fold (0.09 log units) above the measured one; the measured number falls inside the stated range.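

In this assay compound 3 gives 16200 nM, and 4-chlorophenyl in place of 2-fluorophenyl amounts to a 1.3-fold higher number from compound 1 to compound 3 (0.11 log units; within the scatter), so these two groups on the aromatic nitrogen are not separated. Compound 2 gives > 20000 nM, which is a limit of the assay and not a number. The chlorine shift on the phenyl group therefore yields only a floor, an at least 1.2-fold lower number from compound 2 to compound 3 (0.09 log units; that floor lies within the scatter), and its true size stays open because compound 2 has no number: the limit of > 20000 nM in this assay, at which 1 of the 3 values shown sits.

The compounds shown cover only 2-fluorophenyl, 3-chlorophenyl and 4-chlorophenyl on this nitrogen, and give no step beyond the scatter. On these data alone, what an aminophenyl, a carboxyphenyl or a benzyl group at the same place would give remains open.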